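The source may hold more compounds than are shown below. What is called first, only, known or untested is meant among the compounds shown, and "the series" means these compounds.

In a physicochemical assay for acid dissociation, read by spectrophotometry, compound 1 (`CCOc1cc(CN2CCC(NC(=O)c3ccc(Cl)nc3)CC2)cc(OCC)c1-c1ccc(F)cc1`) gives 7.8 and compound 2 (`CCOc1cc(CN2CCC(NC(=O)c3ccc(N)nc3)CC2)cc(OCc2ccccc2)c1-c1ccc(F)cc1`) gives 7.66, two values that lie within the usual scatter of each other. Compound 3 (`CCOc1cc(CN2CCC(NC(=O)c3cncc(C)c3)CC2)cc(OCC)c1-c1ccc(F)cc1`) departs from compound 1 in one place, with 5-methylpyridin-3-yl in place of 6-chloropyridin-3-yl on a carbonyl carbon. Among the measured compounds shown here, no measured pair shows this change on its own, so the expectation rests on those two close values. The expected change, no change at the digits printed from compound 1 to compound 3 (within the scatter), is estimated to stay within the scatter of this assay, with a higher read-out expected as much as a lower one. Compound 3 is expected at 7.8, with an estimated range from 7.4 to 8.2.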

Compound 3, acid dissociation constant: 7.69
Estimate against measurement, compound 3: 0.11 log units above; low and high end bracket the measured number.
By their numbers in this assay, from the lowest: compounds 2, 3 and 1 (each within the scatter of the next).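

In this assay, putting 5-methylpyridin-3-yl in place of 6-chloropyridin-3-yl on a carbonyl carbon gives a number 0.11 log units lower from compound 1 to compound 3 (within the scatter). Among the compounds shown here, this is the first change in one place alone, and it shows that the read-out does not separate these two groups on the shared core, which compounds 1 and 2, differing in more than one place, could not show. Nothing at hand offers an explanation for this result. As far as these compounds go, it remains open whether the read-out would stay within the scatter with a group of another kind on that carbonyl carbon, such as a carboxylic acid or a longer alkyl chain.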